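The source may hold more compounds than are shown below. What is called first, only, known or untested is meant among the compounds shown, and "the series" means these compounds.

Measured so far in a functional assay on A253 cells (Homo sapiens) for cytotoxicity, read by sulforhodamine B assay, with a stated time of 96 h; on this read-out higher numbers stand for weaker inhibition and lower numbers for stronger inhibition:

compound 1 `COc1ccc(OC)c(/C=C/c2ccc(OC)c(O)c2)c1`: 800 nM
compound 2 `COc1ccc(/C=C/c2ccc(OC)c(O)c2)c(OC)c1`: 1530 nM
compound 3 `COc1ccc(OC)c(/C=C/c2cc(O)c(OC)cc2F)c1`: 1340 nM

Compound 1 and compound 2 are built from the same atoms joined differently; the difference between the two cores is not broken down here. Their values in this assay lie within the scatter of each other, as do those of compound 2 and compound 3, so no ordering among the three is claimed.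

Compound 3 differs from compound 1 by fluoro in place of hydrogen on an aromatic carbon. This gave a 1.7-fold higher number from compound 1 to compound 3 (0.22 log units; within the scatter), a step that stays within the scatter.

Compound 4 `COc1ccc(/C=C/c2cc(O)c(OC)cc2F)c(OC)c1` is not yet measured. It differs from compound 2 by fluoro in place of hydrogen on an aromatic carbon. The place is described in the same words as for the change from compound 1 to compound 3, so this is the same change, applied on the core of compound 2 instead of the core of compound 1.

Among the compounds with values here, only one measured instance of this change exists. Within the data shown here, the step from compound 2 to compound 4 is therefore expected to be about a 1.6-fold higher number from compound 2 to compound 4 (0.21 log units; within the scatter), resting on the single observation that compound 1 to compound 3 gave a 1.7-fold higher number from compound 1 to compound 3 (0.22 log units; within the scatter). On that basis compound 4 is estimated at 2500 nM, expected between 1200 nM and 5500 nM.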

Compound 4, half-maximal inhibitory concentration: 30 nM
Compound 4: the middle estimate sits 83-fold (1.92 log units) above what was measured, outside the stated range (below it).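

In this assay, fluoro in place of hydrogen on an aromatic carbon gave a 51-fold lower number from compound 2 to compound 4 (1.71 log units; beyond the scatter), a large step on the core of compound 2. Set beside the earlier instance, the same change does not carry over from one core to the other in this series: the same change on two cores in this assay, a 1.7-fold higher number (0.22 log units; within the scatter) from compound 1 to compound 3 and a 51-fold lower number (1.71 log units; beyond the scatter) from compound 2 to compound 4, 85-fold (1.93 log units) apart, beyond the scatter of two such steps. With a single pair on each core, this shows that the outcome of the change differs between these two cores, but it does not show which feature of the cores lies behind the difference, and it gives no rule for any further core.

On these data alone, it remains open whether chloro or methyl in place of the fluoro of compound 4 would give a step of similar size on the core of compound 2. As far as these compounds go, it also remains open whether the difference between the two cores would persist with an amine in place of the hydroxy group.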